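Replacing tert-butyl with 4-methoxyphenyl in compound 2

The source may report more compounds than this note shows. Statements on the series, on what has been measured and on what is new or still open speak of the compounds shown alone.

Compound 1 `O=C1O[C@H]([C@@H](O)Cn2cc(CNS(=O)(=O)c3ccc(F)cc3)nn2)C(OCc2ccccc2)=C1OCc1ccccc1` gives 34700 nM in a functional assay on CFPAC-1 cells (Homo sapiens) for antiproliferative activity, read by MTT assay, with a stated time of 72 h; on this read-out higher numbers stand for weaker inhibition and lower numbers for stronger inhibition.
Compound 2 `CC(C)(C)c1cn(C[C@H](O)[C@H]2OC(=O)C(OCc3ccccc3)=C2OCc2ccccc2)nn1` gives 54900 nM in this assay.
Compound 3 `O=C1O/C(=C\Cn2cc(-c3cccc(O)c3)nn2)C(OCc2ccccc2)=C1OCc1ccccc1` gives 33700 nM in this assay.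

Compound 2 has the largest of the three numbers, yet its gaps to compound 1 and compound 3 both lie within the scatter, so none of the three stands apart. Compound 4 `COc1ccc(-c2cn(C[C@H](O)[C@H]3OC(=O)C(OCc4ccccc4)=C3OCc3ccccc3)nn2)cc1` differs from compound 2 by 4-methoxyphenyl in place of tert-butyl on an aromatic carbon. For the measured compounds named here, the only measured step at this position, a 1.6-fold higher number from compound 1 to compound 2 (0.20 log units; within the scatter), stayed within the scatter, and compound 3, which carries an aromatic ring at the same position on a different linker, shows a number no different from the others. No step beyond the scatter is therefore expected, and compound 4 is estimated at 45000 nM, in the range 15000 nM to 130000 nM, an expected 1.2-fold lower number from compound 2 to compound 4 (0.09 log units; within the scatter).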

Compound 4, half-maximal inhibitory concentration: 26000 nM
Estimate against measurement, compound 4: 1.7-fold (0.24 log units) above; measured number inside the range.
By their numbers in this assay, from the lowest: compounds 4, 3, 1 and 2 (each within the scatter of the next, the first and the last beyond it).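

For the compounds shown here, at this aromatic carbon, 4-methoxyphenyl in place of tert-butyl gives the first step beyond the scatter, though a modest one (a 2.1-fold lower number from compound 2 to compound 4 (0.32 log units; beyond the scatter)). In place of (((4-fluorophenyl)sulfonyl)amino)methyl, the same group gives a step within the scatter (a 1.3-fold lower number from compound 1 to compound 4 (0.13 log units; within the scatter)), so the position does not separate these two groups. Nothing measured here accounts for the step.

Going by these compounds, it remains open whether the aromatic ring alone or its methoxy group matters. A plain phenyl, or an amine or carboxylic acid on that ring, would help to tell these apart.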